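Swapping the Aromatic Arm on a Shared Amine Core

The compounds below may be only part of what the source reports. "The series", "measured", "known", "first", "only" and "open" are said of these compounds alone.

Measured compounds:
- compound 1 `c1ccc2c(c1)CN[C@@H](CN(CC1CCNCC1)[C@H]1CCCc3cccnc31)C2`: 65% in an ADME assay on microsomes from liver (Rattus norvegicus) for metabolic stability, read by LC-MS, with a stated time of 10 min, tested at 0.5 uM; a lower number here means that less of the compound is left, a higher number that more of the compound is left
- compound 2 `c1ccc2c(c1)CN[C@@H](CN(CC[C@H]1CCCNC1)[C@H]1CCCc3cccnc31)C2`: 55%
- compound 3 `c1cnc(CN(CCCN2CCNCC2)[C@H]2CCCc3cccnc32)nc1`: 68%

Compound 3 gives the largest of the three numbers in this assay, but its gap to compound 1 lies within the usual scatter, so the two cannot be ordered; only compound 2 sits beyond the scatter, with less compound remaining.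

Compound 4 `c1cnc2c(c1)CCC[C@@H]2N(CCCN1CCNCC1)Cc1nc2ccccc2s1` is not yet measured. It differs from compound 3 in one place: 1,3-benzothiazol-2-yl in place of pyrimidin-2-yl on a saturated chain carbon bound to an amine nitrogen

For the measured compounds named here, the single measured step, a number 10 percentage points lower from compound 1 to compound 2 (within the scatter), concerns the chain amine side of the core rather than the aromatic arm, so no measured step bears directly on this change. Going by the values given here, with no direct precedent, the expectation for compound 4 in this assay is a modest fall, expressed as a number 18 percentage points lower from compound 3 to compound 4 (beyond the scatter), with wide uncertainty. Compound 4 is therefore estimated at 50%, within a range from 25% to 75%.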

Compound 4, percent of the compound remaining: 21%
For compound 4 the middle estimate is 29 percentage points above the measured one; the measured number lies below the stated range.
By their numbers in this assay, from the lowest: compound 4; then compounds 2, 1 and 3 (each within the scatter of the next, the first and the last beyond it).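

In this assay, the arm on a saturated chain carbon bound to an amine nitrogen proves to be a sensitive place: putting 1,3-benzothiazol-2-yl in place of pyrimidin-2-yl gives a number 47 percentage points lower from compound 3 to compound 4 (beyond the scatter), a large step. For the compounds shown here, the earlier step concerned only the chain amine side, so this is the first evidence that a change to the aromatic arm alone can shift the read-out this far. The new arm brings a sulfur and a six-membered aromatic ring of carbon only, but nothing available here shows why the number falls.

From the compounds shown here alone, it remains open which part of the new arm matters, and a single-ring 1,3-thiazol-2-yl arm would help separate the two. Going by these compounds, it is also open whether the same swap would give a similar fall with a piperidin-4-yl chain in place of the piperazine-bearing propyl chain.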